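A few compounds are considered here, and "the series" means these few. Any claim that something is new, unique, unknown or untested is made for them only; others in the source may bear on it.

Three close relatives of one scaffold have been examined in an ADME assay on HEK293 cells (Homo sapiens) for cytotoxicity, read by ATP content, with a stated time of 6 h; on this read-out lower numbers stand for higher toxicity in this test and higher numbers for lower toxicity in this test. Compound 1, `Nc1nc(NCc2ncco2)c2c(ccn2Cc2ccccn2)n1`, carries a (1,3-oxazol-2-yl)methyl group on the ring nitrogen of the shared core. In this assay compound 1 gives > 24000 nM, which is a limit of the assay rather than a number. Compound 2, `Cc1coc(CNc2nc(N)nc3ccn(Cc4ccccn4)c23)n1`, differs from compound 1 by methyl in place of hydrogen on an aromatic carbon. In this assay compound 2 gives > 24000 nM, again a limit. Compound 3, `Nc1nc(NCc2ccon2)c2c(ccn2Cc2ccccn2)n1`, differs from compound 1 by 1,2-oxazol-3-yl in place of 1,3-oxazol-2-yl on a saturated chain carbon bound to a nitrogen on an aromatic ring. In this assay compound 3 gives > 24000 nM, also a limit.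

Because all three sit at the limit of > 24000 nM in this assay, at which 3 of the 3 values shown sit, none of the steps between them can be sized: a step that the two limits leave unreadable from compound 1 to compound 2, a step that the two limits leave unreadable from compound 1 to compound 3 and a step that the two limits leave unreadable from compound 2 to compound 3 are all unreadable.

Compound 4, `Cc1cc(CNc2nc(N)nc3ccn(Cc4ccccn4)c23)no1`, has not yet been measured. It differs from compound 3 by methyl in place of hydrogen on an aromatic carbon. Going by the values given here, this is the same kind of change as the one from compound 1 to compound 2, though not the same: in compound 2 the methyl sits next to the ring nitrogen, two ring bonds from the ring oxygen, whereas in compound 4 it sits next to the ring oxygen, two ring bonds from the ring nitrogen. Since compound 1, compound 2 and compound 3 all rest at the limit (the limit of > 24000 nM in this assay, at which 3 of the 3 values shown sit), compound 4 is expected to do the same, with an estimated step that the limit leaves unreadable from compound 3 to compound 4. For compound 4 the estimate in this assay is 30000 nM, within 15000 nM to 70000 nM.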

Compound 4, half-maximal cytotoxic concentration: > 24000 nM
Compound 4 was reported as a limit; the forecaster's own chance of this, stated with the estimate: 85%; the middle value is on the limit's open side.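

Compound 4 gives > 24000 nM in this assay, again a limit of the assay and not a number. No step between compound 4 and compound 1, compound 2 or compound 3 can be read, because all four compounds rest at the same limit: the limit of > 24000 nM in this assay, at which 4 of the 4 values shown sit.

The compounds shown leave open whether any of the four differs from the others in this assay, and by how much.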